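The source may hold more compounds than are shown below. What is called first, only, known or untested is meant among the compounds shown, and "the series" means these compounds.

Measured compounds:
- compound 1 `CC(C)=CCC/C(C)=C/CC/C(C)=C/CC[C@@H]1[C@@]2(C)CC/C(=N\OCc3cn(-c4cccc([N+](=O)[O-])c4)nn3)C(C)(C)[C@@H]2CC[C@@]1(C)O` — 14800 nM
- compound 2 `CC(C)=CCC/C(C)=C/CC/C(C)=C/CC[C@@H]1[C@@]2(C)CC/C(=N\OCc3cn(-c4ccc(F)c(Cl)c4)nn3)C(C)(C)[C@@H]2CC[C@@]1(C)O` — 21400 nM
- compound 3 `CC(C)=CCC/C(C)=C/CC/C(C)=C/CC[C@@H]1[C@@]2(C)C/C(=C\c3ccc(OCc4cn(-c5ccc(F)cc5)nn4)cc3)C(=O)C(C)(C)[C@@H]2CC[C@@]1(C)O` — 55200 nM

In a functional assay on A549 cells (Homo sapiens) for cytotoxicity, read by MTT assay, with a stated time of 48 h (on this read-out higher numbers stand for weaker inhibition and lower numbers for stronger inhibition), compound 3 gives the highest number of the three, beyond the scatter from compound 2 and from compound 1. Compound 4 `CC(C)=CCC/C(C)=C/CC/C(C)=C/CC[C@@H]1[C@@]2(C)C/C(=C\c3ccc(OCc4cn(-c5cccc([N+](=O)[O-])c5)nn4)cc3)C(=O)C(C)(C)[C@@H]2CC[C@@]1(C)O` differs from compound 3 only at the triazole: 3-nitrophenyl in place of 4-fluorophenyl on an aromatic nitrogen. Among the compounds with values here, the one measured step that touches a similar exchange, a 1.4-fold higher number from compound 1 to compound 2 (0.16 log units; within the scatter), swaps a nitrophenyl for a halogenated phenyl on a different core and stays within the scatter. On that basis the number for compound 4 is expected to sit close to that of compound 3, perhaps slightly lower, with the step of a 1.2-fold lower number from compound 3 to compound 4 (0.09 log units; within the scatter) likely within the scatter. Compound 4 is therefore estimated at 45000 nM, in the range 20000 nM to 110000 nM.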

Compound 4, half-maximal inhibitory concentration: 126000 nM
Compound 4: middle estimate off by 2.8-fold (0.45 log units), on the low side; measured number outside the range, above it.
By their numbers in this assay, from the lowest: compounds 1 and 2 (each within the scatter of the next); then compound 3; then compound 4.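

In this assay, the group on the aromatic nitrogen does affect the read-out on this core: with 3-nitrophenyl in place of 4-fluorophenyl, a 2.3-fold higher number from compound 3 to compound 4 (0.36 log units; beyond the scatter), meaning weaker inhibition. The earlier exchange on the other core, a 1.4-fold higher number from compound 1 to compound 2 (0.16 log units; within the scatter), gave no such sign, though it involved a different halogenated phenyl, so the two steps are not a strict match. Nothing measured here gives a reason for this step.

Going by these compounds, whether a plain phenyl or an aminophenyl at this position would give a lower number remains open. So does whether 4-fluorophenyl and 3-nitrophenyl would separate in the same way on the core of compound 1.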